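Substituent series on the shared core: methoxy to piperidin-1-yl

The source may report more compounds than this note shows. Statements on the series, on what has been measured and on what is new or still open speak of the compounds shown alone.

Measured so far, in a functional assay on HeLa cells (Homo sapiens) for antiproliferative activity, read by MTT assay, with a stated time of 48 h; a higher number here means a weaker inhibitor, a lower number a stronger inhibitor:
compound 1, `Cc1cnc(Nc2ccc(S(N)(=O)=O)cc2)nc1Nc1nc2ccccc2s1`, gives 2800 nM.
compound 2, `Cc1cnc(Nc2ccc(F)cc2)nc1Nc1nc2ccccc2s1`, gives only a limit, > 50000 nM.
compound 3, `COc1ccc(Nc2ncc(C)c(Nc3nc4ccccc4s3)n2)cc1`, gives only a limit, > 50000 nM.

Compound 3 therefore stands at the limit of this assay and not at a number, sharing that limit with one other value in the set (the limit of > 50000 nM in this assay, at which 2 of the 3 values shown sit). Relative to compound 1, the change from sulfamoyl to methoxy gave an at least 17-fold higher number from compound 1 to compound 3 (1.25 log units; beyond the scatter), and the change from sulfamoyl to fluoro gave an at least 17-fold higher number from compound 1 to compound 2 (1.25 log units; beyond the scatter). Between compound 2 and compound 3 the two limits leave the step unreadable: a step that the two limits leave unreadable from compound 2 to compound 3.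

Compound 4, `Cc1cnc(Nc2ccc(N3CCCCC3)cc2)nc1Nc1nc2ccccc2s1`, differs from compound 3 in one place: piperidin-1-yl in place of methoxy on an aromatic carbon. For the measured compounds named here, no measured step in the set exchanges methoxy for piperidin-1-yl, and the only readable steps at this position run from the sulfamoyl of compound 1 to two limits. Since compound 3 sits at a limit, the expected step of an at least 2.5-fold lower number from compound 3 to compound 4 (0.39 log units; beyond the scatter) is an estimate whose direction the data do not fix. The number for compound 4 in this assay is expected at 20000 nM, within 4000 nM to 50000 nM, with a fair chance that only a limit is reported again.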

Compound 4, half-maximal inhibitory concentration: 4340 nM
The estimate for compound 4 lay 4.6-fold (0.66 log units) above the measured number, and the stated range covers the measured number.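

In this assay, piperidin-1-yl on this aromatic carbon gives a readable number where methoxy and fluoro do not, with an at least 11-fold lower number from compound 3 to compound 4 (1.06 log units; beyond the scatter) and an at least 11-fold lower number from compound 2 to compound 4 (1.06 log units; beyond the scatter). Sulfamoyl is therefore not the only group at this position that gives a readable number, and against compound 1 the change to piperidin-1-yl gave a 1.6-fold higher number from compound 1 to compound 4 (0.19 log units; within the scatter), so these two compounds cannot be told apart in this assay. Methoxy and piperidin-1-yl each count 0 hydrogen-bond donors, 1 hydrogen-bond acceptor and no net charge, so these counts do not separate compound 3 from compound 4, whereas the heavy-atom count and the six-membered non-aromatic ring do.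

The compounds shown do not tell whether the ring carbons or the nitrogen of piperidin-1-yl go with the change, a question that a cyclohexyl, a morpholin-4-yl or an open-chain dimethylamino group at this place would address. The step between the fluoro and methoxy compounds cannot be read, so those two groups remain unordered: the limit of > 50000 nM in this assay, at which 2 of the 4 values shown sit.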